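This account rests on a few compounds, and the source may have more. Where it says the series, first, only, none or still open, it means among the compounds named here.

Values in an ADME assay on S9 fraction from liver (Rattus norvegicus) for metabolic stability, with a stated time of 1 h (on this read-out higher numbers stand for a more stable compound and lower numbers for a less stable compound), so far:
- compound 1 `N#Cc1cnc(NCc2cnccc2C(F)(F)F)cc1NC[C@H]1C[C@@H](O)C1` gives 44%
- compound 2 `N#Cc1cnc(NCc2cnccc2C(F)(F)F)cc1N[C@H]1CC[C@H](O)CC1` gives 25%
- compound 3 `N#Cc1cnc(NCc2cnccc2C(F)(F)F)cc1NC[C@H]1CC[C@@H](O)CC1` gives 18%

Compound 3 sits at the low end of this small set together with compound 2, as the step is a number 7 percentage points lower from compound 2 to compound 3 (within the scatter) here. Against compound 1 the picture differs, with a number 26 percentage points lower from compound 1 to compound 3 (beyond the scatter) on record.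

Compound 4 `N#Cc1cnc(NCc2cnccc2C(F)(F)F)cc1NC[C@H]1CC[C@H](O)CC1` keeps the atoms and bonds of compound 3 and differs only in configuration as drawn (the two compounds have the same atoms and bonds and differ only in configuration as drawn: 2 of 2 stereo elements differ (all stereocentres are inverted: mirror images); a stereocentre at a saturated ring carbon is drawn s in compound 3 and r in compound 4; a stereocentre at a saturated ring carbon is drawn s in compound 3 and r in compound 4).

Going by the values given here, no measured pair isolates a change of configuration, so the evidence is indirect. The modest steps, a number 19 percentage points lower from compound 1 to compound 2 (beyond the scatter) and a number 26 percentage points lower from compound 1 to compound 3 (beyond the scatter), both involve a change in the group carrying the hydroxyl. Among the compounds with values here, the one step among the cyclohexyl compounds, a number 7 percentage points lower from compound 2 to compound 3 (within the scatter), stays small. On that basis no step beyond the scatter is expected in this assay, with at most a slight drift upward. The expected step is a number 4 percentage points higher from compound 3 to compound 4 (within the scatter) as an estimate. For compound 4 the estimated value is 22%, with an expected range from 10% to 38%.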

Compound 4, percent of the compound remaining: 6%
Estimate against measurement, compound 4: 16 percentage points above, and the stated range ends above it.
By their numbers in this assay, from the lowest: compound 4; then compounds 3 and 2 (each within the scatter of the next); then compound 1.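

In this assay, configuration alone moves the read-out within the (4-hydroxycyclohexyl)methyl compounds, with a number 12 percentage points lower from compound 3 to compound 4 (beyond the scatter), and this step can be assigned to stereochemistry because nothing else changes: the fact that compounds 3 and 4 differ only in the configuration as drawn. The exchange of 4-hydroxycyclohexyl for (4-hydroxycyclohexyl)methyl stayed within the scatter in the earlier comparison, yet with the other configuration it gives a number 19 percentage points lower from compound 2 to compound 4 (beyond the scatter), so the outcome of that exchange depends on the stereoisomer compared. The gap to the cyclobutyl compound also depends on configuration, widening to a number 38 percentage points lower from compound 1 to compound 4 (beyond the scatter).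

From the compounds shown here alone, whether inverting the stereocentres of compound 1 or compound 2 would shift this assay in a similar way remains open. Also open, going by these compounds, is how a carboxylic acid or a primary amine in place of the hydroxyl would read in this assay.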